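Chloro to bromo on the shared core: working notes

The source may report more compounds than this note shows. Statements on the series, on what has been measured and on what is new or still open speak of the compounds shown alone.

Measured so far:
Compound 1, `COc1ccc2[nH]c(=O)c(-c3nc4ccccc4[nH]3)cc2c1`: in a functional assay on HepG2 cells (Homo sapiens) for cytotoxicity, read by MTT assay, with a stated time of 48 h (a lower number here means a stronger inhibitor, a higher number a weaker inhibitor), compound 1 gives > 100000 nM, which is a limit of the assay and not a number.
Compound 2, `Cc1ccc2[nH]c(=O)c(-c3nc4cc(Cl)ccc4[nH]3)cc2c1`: in this assay compound 2 gives 26600 nM.
Compound 3, `COc1ccc2[nH]c(=O)c(-c3nc4cc(C)c(C)cc4[nH]3)cc2c1`: in this assay compound 3 gives > 100000 nM, again a limit of the assay.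

Among the compounds with values here, compound 2 thus carries the only actual number in the set; the other two values sit at the limit of > 100000 nM in this assay, at which 2 of the 3 values shown sit. Within the data shown here, no pair of measured compounds differs in a single place, so the set itself gives no measured step from which the size of a change could be read.

Compound 4, `Cc1ccc2[nH]c(=O)c(-c3nc4cc(Br)ccc4[nH]3)cc2c1`, is not yet measured. It differs from compound 2 as follows: bromo in place of chloro on an aromatic carbon. The chloro leaves and the bromo enters at the same aromatic carbon of the six-membered aromatic ring of carbon only, meta to a fused ring and para to a fused ring. An exchange of one halogen for the other at that carbon is expected to shift this assay by no more than the usual scatter, in no settled direction. The step of a 1.1-fold lower number from compound 2 to compound 4 (0.03 log units; within the scatter) is expected to be small. In this assay compound 4 is estimated at 25000 nM, between 10000 nM and 70000 nM.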

Compound 4, half-maximal inhibitory concentration: > 100000 nM
Compound 4 gave a limit, no number; the forecaster's own chance of this, stated with the estimate: 20%; middle value at least 4.0-fold (0.60 log units) away from the limit.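

Within the data shown here, the exchange gives the first measured step: bromo in place of chloro on this aromatic carbon, meta to a fused ring and para to a fused ring, gives an at least 3.7-fold higher number from compound 2 to compound 4 (0.57 log units; beyond the scatter) in this assay. This carbon therefore does not treat the two halogens alike, and the chloro of compound 2 cannot be swapped for bromo without a change beyond the scatter. The value of compound 4 is a limit of the assay, so the step gives only a lower bound on the change: the limit of > 100000 nM in this assay, at which 3 of the 4 values shown sit.

Open, going by these compounds, is whether fluoro, a nitrile or an amine at this carbon would give a number in this assay or a limit. Also open, on these data alone, is whether the same halogen exchange gives a similar step on a core carrying methoxy in place of methyl.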